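The source may hold more compounds than are shown below. What is called first, only, known or untested is meant among the compounds shown, and "the series" means these compounds.

Of the compounds shown here, three sharing one core have been measured in a functional assay on KMS-11 cells (Homo sapiens) for antiproliferative activity, read by CellTiter-Glo, with a stated time of 72 h; on this read-out lower numbers stand for stronger inhibition and higher numbers for weaker inhibition. Compound 1 `COc1ccc(C(=O)N(Cc2ccncc2)Cc2cccc(OCCc3ccc(C)cc3)c2)cc1` gives 9100 nM, compound 2 `COc1ccc(C(=O)N(Cc2ccncc2)Cc2cccc(OCCc3cccc(C(F)(F)F)c3)c2)cc1` gives 8900 nM, and compound 3 `COc1ccc(C(=O)N(Cc2ccncc2)Cc2cccc(OCC3CCCCC3)c2)cc1` gives 19700 nM. Compound 3 therefore has the highest number of the three and is the weakest inhibitor so far.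

Compound 4 `COc1ccc(C(=O)N(Cc2ccncc2)Cc2cccc(OCCc3ccc(Br)cc3)c2)cc1` differs from compound 3 in one place: 4-bromobenzyl in place of cyclohexyl on a saturated chain carbon bound to an oxygen on an aromatic ring. Here, 4-bromobenzyl stands in place of cyclohexyl on a saturated chain carbon bound to an oxygen on an aromatic ring.

Two measured steps make a closely related swap in the opposite direction, replacing a substituted benzyl group with cyclohexyl: a 2.2-fold higher number from compound 1 to compound 3 (0.34 log units; beyond the scatter), and a 2.2-fold higher number from compound 2 to compound 3 (0.35 log units; beyond the scatter). Both are modest but beyond the scatter. Read backwards, they suggest that bringing a substituted benzyl group back should lower the number by a similar amount. The choice between the 4-methylbenzyl and 3-(trifluoromethyl)benzyl groups shows no measurable effect, with a 1.0-fold lower number from compound 1 to compound 2 (0.01 log units; within the scatter). However, only these two groups have been compared, and no bromine-bearing compound has been measured.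

The expected change in this assay is therefore a modest fall, a 2.2-fold lower number from compound 3 to compound 4 (0.34 log units; beyond the scatter). For compound 4 the estimate is 9000 nM, with an expected range from 5000 nM to 16000 nM.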

Compound 4, half-maximal inhibitory concentration: 8400 nM
Compound 4: middle estimate off by 1.1-fold (0.03 log units), on the high side; measured number inside the range.
By their numbers in this assay, from the lowest: compounds 4, 2 and 1 (each within the scatter of the next); then compound 3.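

In this assay, 4-bromobenzyl is a third group that separates from cyclohexyl at this position, with a 2.3-fold lower number from compound 3 to compound 4 (0.37 log units; beyond the scatter), so the gap to cyclohexyl now holds for three different substituted aromatic groups rather than two. Bromo in place of methyl on an aromatic carbon leaves no readable difference, with a 1.1-fold lower number from compound 1 to compound 4 (0.03 log units; within the scatter), and neither does moving to 4-bromophenyl from 3-(trifluoromethyl)phenyl, with a 1.1-fold lower number from compound 2 to compound 4 (0.03 log units; within the scatter), so compounds 1, 2 and 4 form one group whose aromatic substituent has so far changed nothing beyond the scatter. No supporting measurement is available to explain these numbers.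

The step away from cyclohexyl changes the ring and the chain together, as the reading cyclohexylmethyl to 2-(4-bromophenyl)ethyl shows, so these compounds cannot say which of the two changes matters; a 2-cyclohexylethyl or a benzyl group on the same oxygen would separate them. Going by these compounds, it also stays open whether an unsubstituted phenyl ring, or one carrying an amine or a carboxylic acid, would fall with these three compounds or move away from them.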